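A nitro group added to compound 1

The source may report more compounds than this note shows. Statements on the series, on what has been measured and on what is new or still open speak of the compounds shown alone.

Compound 1 `COc1ccc(/C=C/C(=O)/C(C)=C/c2ccccc2)cc1` gives 93000 nM
Compound 2 `C/C(=C\c1ccccc1)C(=O)/C=C/c1ccc([N+](=O)[O-])cc1` gives 43300 nM

In an ADME assay on LLC-MK2 cells (Macaca mulatta) for cytotoxicity, read by MTT assay, with a stated time of 48 h (a higher number here means that more compound is tolerated, a lower number that less compound is tolerated), compound 1 (93000 nM) stands highest of the two measured compounds. Compound 3 `COc1ccc(/C=C/C(=O)/C(C)=C/c2ccc([N+](=O)[O-])cc2)cc1` differs from compound 1 by one change (nitro in place of hydrogen on an aromatic carbon) that is nitro in place of hydrogen on an aromatic carbon. Within the data shown here, the only measured step bearing on it (a 2.1-fold lower number from compound 1 to compound 2 (0.33 log units; beyond the scatter)) is modest and puts nitro in place of methoxy, a group compound 3 keeps. A drop of similar size is therefore expected in this assay with considerable uncertainty. For compound 3 the expected step (a 2.1-fold lower number from compound 1 to compound 3 (0.32 log units; beyond the scatter)) stays modest. Compound 3 is estimated at 45000 nM with a range (18000 nM to 100000 nM).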

Compound 3, half-maximal cytotoxic concentration: 172000 nM
The estimate for compound 3 lay 3.8-fold (0.58 log units) below the measured number; measured number above the stated range.
By their numbers in this assay, from the lowest: compound 2; then compounds 1 and 3 (each within the scatter of the next).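

In this assay, nitro in place of hydrogen on an aromatic carbon para to a large group leaves the number within the scatter (a 1.8-fold higher number from compound 1 to compound 3 (0.27 log units; within the scatter)). The drop seen when nitro replaced methoxy (a 2.1-fold lower number from compound 1 to compound 2 (0.33 log units; beyond the scatter)) therefore does not carry over to this position, at least with methoxy kept on the core. No measurement at hand accounts for this difference between the two positions. As far as these compounds go, whether an amine or a carboxylic acid at this position would also stay within the scatter remains open.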